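The source may report more compounds than this note shows. Statements on the series, on what has been measured and on what is new or still open speak of the compounds shown alone.

In a functional assay on HUVEC cells (Homo sapiens) (on this read-out higher numbers stand for an effect only at larger amounts of compound and lower numbers for an effect already at smaller amounts), compound 1 `COC1=C(C)C(=O)/C(=C(O)/C=C/c2ccc(C)cc2)C(=O)C1(C)C` gives < 4 ug/mL, which is a limit of the assay and not a number. Compound 2 `COC1=C(C)C(=O)/C(=C(O)/C=C/c2c(C)cc(C)cc2C)C(=O)C1(C)C` gives < 4 ug/mL, which is also a limit. The data so far therefore consist only of the limit of < 4 ug/mL in this assay, at which 2 of the 2 values shown sit, and compound 1 has no exact position on the scale. Compound 3 `COC1=C(C)C(=O)/C(=C(O)/C=C/c2cccs2)C(=O)C1(C)C` keeps the core of compound 1 but carries thiophen-2-yl in place of 4-methylphenyl on a double-bonded chain carbon bound to a double-bonded chain carbon. Going by the values given here, no measured step shows what such an exchange does in this assay, so no change beyond the usual scatter is expected, and neither direction is favoured. The estimated change is a step that the limit leaves unreadable from compound 1 to compound 3. This expectation rests on compound 1 at < 4 ug/mL, itself a limit, and a further limit would be a likely report for the new compound. For compound 3 the expected value is 2.5 ug/mL, with an estimated range of 0.8 ug/mL to 6 ug/mL.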

Compound 3, concentration for half-maximal effect: < 4 ug/mL
Compound 3: no number, only a limit; the forecaster's own chance of this, stated with the estimate: 65%; the middle value does not contradict the limit.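

Going by these compounds alone, compound 3, like compound 1, is reported in this assay only as a limit and not as a number, so thiophen-2-yl in place of 4-methylphenyl gives no step that can be read: the limit of < 4 ug/mL in this assay, at which 3 of the 3 values shown sit. The compounds shown leave open where their actual values lie and whether they differ from one another at all.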